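The compounds below may be only part of what the source reports. "The series", "measured", "known", "first", "only" and "open" are said of these compounds alone.

Of the compounds shown here, two with a shared core have been measured in an assay on membranes from Cortex for displacement of a labelled ligand from Sigma non-opioid intracellular receptor 1 (Cavia porcellus), read by scintillation counting, with a stated time of 120 min; on this read-out lower numbers stand for stronger inhibition and higher numbers for weaker inhibition. Compound 1 `O=C(c1ccc(F)cc1)N1CCC(NCC[S+]([O-])C(c2ccc(F)cc2)c2ccc(F)cc2)CC1`, in which the sulfur of the chain carries an oxygen as a sulfoxide and the amide carbonyl bears a 4-fluorophenyl group, gives 1440 nM. Compound 2 `O=C(C1CC1)N1CCC(NCCSC(c2ccc(F)cc2)c2ccc(F)cc2)CC1` is the other one, and it differs from compound 1 in several places at once; in this assay compound 2 gives 46.4 nM. Of the two numbers, compound 1 stands at the higher one, meaning the weaker binding, and the gap to compound 2 lies beyond the scatter, though the two compounds differ in several places at once, so nothing can be said about which part of the difference carries that gap.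

Compound 3 `O=C(c1ccc(F)cc1F)N1CCC(NCC[S+]([O-])C(c2ccc(F)cc2)c2ccc(F)cc2)CC1` changes compound 1 in one place only: fluoro in place of hydrogen on an aromatic carbon. Going by the values given here, no measured pair in this set isolates the effect of such a fluoro, so the size of the step has to be guessed. The expectation for the step from compound 1 to compound 3 is a 1.1-fold lower number from compound 1 to compound 3 (0.04 log units; within the scatter), that is, no change beyond the scatter in either direction. Compound 3 is therefore estimated to give 1300 nM in this assay, with a likely range from 500 nM to 3500 nM.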

Compound 3, inhibition constant: 171 nM
Compound 3: middle estimate off by 7.6-fold (0.88 log units), on the high side; the whole stated range lies above it.
By their numbers in this assay, from the lowest: compound 2; then compound 3; then compound 1.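

Replacing the 4-fluorophenyl on the amide carbonyl with 2,4-difluorophenyl gives an 8.4-fold lower number from compound 1 to compound 3 (0.93 log units; beyond the scatter) in this assay, a step beyond the scatter. Going by these compounds alone, this is the first comparison in the set in which only one place differs, and it shows that this aromatic ring is not a silent part of the molecule: a fluoro on a carbon ortho to a large group, a change of 1 heavy atom, is enough to move the read-out clearly. Nothing available here bears on what lies behind a step of this size.

Still open, going by these compounds, is whether the gain belongs to fluoro in particular or would also come with a chloro, methyl or methoxy group on the same carbon, and whether fluoro on another carbon of this ring would do the same. It is also unknown whether the step would carry over to a compound with a plain thioether sulfur in the chain in place of the sulfoxide, since this single pair cannot show how far the effect extends beyond compound 1 and compound 3.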